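The source may hold more compounds than are shown below. What is called first, only, known or untested is meant among the compounds shown, and "the series" means these compounds.

Compound 1 `O=C(NC1CCN(Cc2ccn(-c3ccc(C(F)(F)F)cc3)c2)CC1)N1CCCC(CO)C1` and compound 2 `COc1ccc(OC2CN(C(=O)NC3CCN(Cc4ccn(-c5ccc(C(F)(F)F)cc5)c4)CC3)C2)cc1` were both tested in an assay on HEK293 cells for displacement of a labelled ligand from melanin-concentrating hormone receptor 1 (Homo sapiens); on this read-out lower numbers stand for stronger inhibition and higher numbers for weaker inhibition. In this assay compound 1 gives 23 nM, the lower of the two numbers, while compound 2 gives 49 nM, a higher number that lies beyond the usual scatter. Compound 3 `O=C(O)CC(NC(=O)NC1CCN(Cc2ccn(-c3ccc(C(F)(F)F)cc3)c2)CC1)c1ccccc1` has not yet been measured; it differs from compound 1 in one place: (2-carboxy-1-phenylethyl)amino in place of 3-(hydroxymethyl)piperidin-1-yl on a carbonyl carbon. Among the compounds with values here, no measured pair shows this change, so its effect is unknown. The expected step is a moderate one toward a higher number, estimated at roughly a 4.3-fold higher number from compound 1 to compound 3 (0.64 log units; beyond the scatter). Compound 3 is therefore estimated at 100 nM, within a range from 20 nM to 500 nM.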

Compound 3, half-maximal inhibitory concentration: 412 nM
For compound 3 the middle estimate is 4.1-fold (0.61 log units) below the measured one, and the stated range covers the measured number.
By their numbers in this assay, from the lowest: compound 1; then compound 2; then compound 3.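

Within the data shown here, compound 1 and compound 2 offer no step that differs in one place, whereas this change shows that the group on the carbonyl carbon can strongly affect the result. In this assay, (2-carboxy-1-phenylethyl)amino in place of 3-(hydroxymethyl)piperidin-1-yl gives an 18-fold higher number from compound 1 to compound 3 (1.25 log units; beyond the scatter), a large loss of inhibition. Nothing available explains this loss.

The change swaps the whole group, so the parts played by the carboxy group, the phenyl ring and the lost piperidine ring cannot be separated. A methyl ester in place of the carboxylic acid, or a plain benzylamino group, would help tell them apart.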